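This account rests on a few compounds, and the source may have more. Where it says the series, first, only, none or still open, it means among the compounds named here.

The compounds share one core. Compound 1 `COC(=O)c1c(NC(=O)N2CCN(C)CC2)sc2c1CCCCC2`, carrying a methyl ester and a urea, gives 1330 nM in an assay on cells for agonist activity at Toll-like receptor 2 (Homo sapiens), with a stated time of 24 h; a higher number here means that more compound is needed for the effect, a lower number that less compound is needed. Compound 2 `CCN1CCN(C(=O)Nc2sc3c(c2C(=O)OC(C)C)CCC3)CC1` is reported in this assay as "not active" (no number reported). Compound 3 `CCCOC(=O)c1c(NC(=S)N2CCN(C)CC2)sc2c1CCCC2`, with a thiourea and a propyl ester, is reported in this assay as "not active" (no number reported), so compound 3 stands without a single number, as does one further compound, compound 2. Compound 4 `CC(C)OC(=O)c1c(NC(=S)N2CCN(C)CC2)sc2c1CCCC2` differs from compound 3 by isopropyl in place of propyl on an oxygen next to a carbonyl group; the two have the same atoms, joined differently. Among the compounds with values here, no measured pair shows this change, so no step size can be read; compound 3 is reported as "not active" (no number reported), and the expectation is for no movement beyond the usual scatter from that. Compound 4 is therefore expected to give 12000 nM in this assay, within a range of 2000 nM to 60000 nM, and quite possibly no number at all.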

Compound 4, half-maximal effective concentration: 45200 nM
Estimate against measurement, compound 4: 3.8-fold (0.58 log units) below; low and high end bracket the measured number.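

No step can be read between compound 3 and compound 4, as compound 3 has no single number. The compounds shown leave open how propyl and isopropyl compare when both give a number. No evidence bears on this result.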